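This account rests on a few compounds, and the source may have more. Where it says the series, first, only, none or still open, it means among the compounds named here.

Measured compounds:
compound 1 `O=C(N/N=C/c1ccc(Cl)cc1Cl)Nc1cccc2ccccc12` — 300 mg/kg
compound 2 `COc1cc(/C=N/NC(=O)Nc2cccc3ccccc23)cc(OC)c1OC` — 100 mg/kg
compound 3 `CN(C)c1ccc(/C=N/NC(=O)Nc2cccc3ccccc23)cc1` — 300 mg/kg

In a functional assay on the whole organism (strain Swiss albino) with Mus musculus as the target, with a stated time of 4 h (a higher number here means that more compound is needed for the effect, a lower number that less compound is needed), compound 3 gives 300 mg/kg, level at the digits shown with compound 1, which gives 300 mg/kg; together these two are the highest of the three numbers. Compound 2 gives 100 mg/kg, a lower number than compound 3, beyond the scatter. Compound 4 `O=C(N/N=C/c1ccc([N+](=O)[O-])cc1)Nc1cccc2ccccc12` is obtained from compound 3 by a single change: nitro in place of dimethylamino on an aromatic carbon. Among the compounds with values here, no pair of measured compounds differs by this same exchange, so the numbers give no direction for it. The expected step from compound 3 to compound 4 is no change at the digits printed from compound 3 to compound 4 (within the scatter), that is, no change beyond the scatter. Compound 4 is estimated at 300 mg/kg, with a range from 100 mg/kg to 1000 mg/kg.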

Compound 4, minimum effective dose: 300 mg/kg
The estimate for compound 4 equals the measured number at the digits printed, within the range that was stated.
By their numbers in this assay, from the lowest: compound 2; then compounds 1, 3 and 4 (each within the scatter of the next).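

Within this assay, nitro in place of dimethylamino on an aromatic carbon, para to a large group, gives no change at the digits printed from compound 3 to compound 4 (within the scatter) and is the first step that can be read at this position. The exchange of these two groups, which differ in hydrogen-bond acceptors and atom types but not in heavy-atom count, leaves the number unmoved here. Nothing measured on these compounds offers an explanation for this result. On these data alone, whether a carboxylic acid or a primary amine at this position would move the number remains open.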